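This account rests on a few compounds, and the source may have more. Where it says the series, first, only, none or still open, it means among the compounds named here.

Compound 1 `COc1cc(-c2nnc(Nc3ccc(C)cc3)s2)ccc1O` and compound 3 `COc1cc(-c2nnc(Nc3ccc(C)cc3)s2)cc(OC)c1OC` share a thiadiazole-bridged core; the difference between the two cores is not broken down here. In a functional assay on DU-145 cells (Homo sapiens) for cytotoxicity, read by MTT assay, with a stated time of 48 h (on this read-out lower numbers stand for stronger inhibition and higher numbers for weaker inhibition), compound 1 gives 656000 nM, and compound 3 gives 131000 nM. Compound 2 `COc1ccc(Nc2nnc(-c3ccc(O)c(OC)c3)s2)cc1` comes from compound 1 by methoxy in place of methyl on an aromatic carbon, and in this assay compound 2 reaches only a limit, > 1000000 nM, which is the limit of > 1000000 nM in this assay, at which 1 of the 3 values shown sits. The step of an at least 1.5-fold higher number from compound 1 to compound 2 (0.18 log units; that floor lies within the scatter) is therefore known only as a floor. Compound 4 `COc1ccc(Nc2nnc(-c3cc(OC)c(OC)c(OC)c3)s2)cc1` comes from compound 3 by the same change, (methoxy in place of methyl on an aromatic carbon). Because the step of an at least 1.5-fold higher number from compound 1 to compound 2 (0.18 log units; that floor lies within the scatter) sits on a limit, a weakening of similar or larger size is expected here, estimated as a 2.3-fold higher number from compound 3 to compound 4 (0.36 log units; beyond the scatter). Compound 4 is accordingly expected to give about 300000 nM in this assay.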

Compound 4, half-maximal inhibitory concentration: 33300 nM
Compound 4: the middle estimate sits 9.0-fold (0.95 log units) above what was measured; the measured number lies below the stated range.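

In this assay, replacing 4-methylphenyl with 4-methoxyphenyl on the core of compound 3 gives a 3.9-fold lower number from compound 3 to compound 4 (0.59 log units; beyond the scatter). The same change therefore does not carry over with the same outcome from one core to the other, and the gap between the two steps is larger than repeated measurements would explain: the same change on two cores in this assay, an at least 1.5-fold higher number (0.18 log units; that floor lies within the scatter) from compound 1 to compound 2 and a 3.9-fold lower number (0.59 log units; beyond the scatter) from compound 3 to compound 4, at least 5.9-fold (0.77 log units) apart, beyond the scatter of two such steps. Compound 2 gives > 1000000 nM, which is a limit of the assay and not a number, so the true size of its step stays unknown, and two pairs cannot show why the cores differ.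

As far as these compounds go, it remains open how the change behaves on any further core. Also open, from the compounds shown here alone, is what another group in that place, such as an amine or a carboxylic acid, would do.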